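This account rests on a few compounds, and the source may have more. Where it says the series, first, only, none or still open, it means among the compounds named here.

In an ADME assay on a cell-free system (plasma, Homo sapiens) for protein binding, compound 2 `O=C(Nc1ccc(Cl)c(C(F)(F)F)c1)N[C@H]1CCN(c2ccnc(NC3CC3)n2)C1` stands at > 99.9%, which is a limit of the assay and not a number. In this assay compound 1 `CNc1nccc(N2CC[C@H](NC(=O)Nc3ccc(CN4CCC4)c(C(F)(F)F)c3)C2)n1` gives 86.3% and compound 3 `CNc1nccc(N2CC[C@H](NC(=O)Nc3ccc(OC(F)F)cc3)C2)n1` gives 93.8%. Compound 4 `Nc1nccc(N2CC[C@H](NC(=O)Nc3ccc(Cl)c(C(F)(F)F)c3)C2)n1` differs from compound 2 by hydrogen in place of cyclopropyl on a nitrogen on an aromatic ring, so that 2-(cyclopropylamino)pyrimidin-4-yl becomes 2-aminopyrimidin-4-yl. Within the data shown here, no measured step isolates this change, so its size is a judgement. Compound 3 at 93.8% shows that the series can give a plain measured number. A modest downward step is expected, an at least 15-fold higher unbound fraction from compound 2 to compound 4 (1.17 log units; beyond the scatter). For compound 4 the estimated value is 98.5%, with an expected range of 95.5% to 99.7%.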

Compound 4, plasma protein binding: 99.5%
Beside the measured number, compound 4's estimate is 3.0-fold (0.48 log units) (unbound fraction) above it; the range from low to high includes it.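

In this assay compound 2 stands at > 99.9%, which is a limit of the assay and not a number. Cyclopropylamino to amino on the aromatic ring gives an at least 5.0-fold higher unbound fraction from compound 2 to compound 4 (0.69 log units; beyond the scatter), the first step read at this position, showing that removing cyclopropyl from this nitrogen frees measurable unbound compound. Its true size remains unknown because one end of the step is censored: the limit of > 99.9% in this assay, at which 1 of the 4 values shown sits.

Open, on these data alone, is how an ethyl group or a longer chain carrying a carboxylic acid on this nitrogen would fall relative to hydrogen and cyclopropyl.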